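Trimethoxyphenyl in Place of Methoxyphenyl on the Triazole Core

A few compounds are considered here, and "the series" means these few. Any claim that something is new, unique, unknown or untested is made for them only; others in the source may bear on it.

Measured compounds:
compound 1, `COc1cc(-c2nnc(SCC(=O)Nc3ccc(/C(C)=N/O)cc3)n2-c2ccccc2)cc(OC)c1OC`, 75%
compound 2, `CCn1c(SCC(=O)Nc2ccc(C(C)=O)cc2)nnc1-c1cc(OC)c(OC)c(OC)c1`, 68%
compound 3, `COc1ccc(-c2nnc(SCC(=O)Nc3ccc(C(C)=O)cc3)n2-c2ccccc2)cc1`, 63%

In a functional assay on the whole organism (strain albino) for inhibition, with Rattus norvegicus as the target, read by paw edema, with stated times of 30 min and 4 h, at a dose of 0.28 mmol/kg by the oral route (a lower number here means less inhibition, a higher number more inhibition at the dose given (going by the name of the read-out)), compound 3 gives 63%, the lowest of the three numbers shown. Its nearest neighbour is compound 2, whose value of 68% lies within the scatter of compound 3, so the two cannot be told apart. Compound 1, with 75%, lies beyond the scatter above compound 3.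

The unmeasured compound 4, `COc1cc(-c2nnc(SCC(=O)Nc3ccc(C(C)=O)cc3)n2-c2ccccc2)cc(OC)c1OC`, differs from compound 3 in one place: 3,4,5-trimethoxyphenyl in place of 4-methoxyphenyl on an aromatic carbon. Compound 1 and compound 2 both carry the 3,4,5-trimethoxyphenyl group that enters here, and both sit at or above compound 3 in this assay. Among the measured compounds shown here, no step between measured compounds is available to size this change directly.

On that basis compound 4 is expected to come out somewhat higher than compound 3, with a step of a number 7 percentage points higher from compound 3 to compound 4 (within the scatter) that stays within the scatter rather than clearly beyond it. The estimate for compound 4 in this assay is 70%, with a range from 60% to 80%.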

Compound 4, a percentage reported as inhibition, in the whole organism at one dose (the size of the read-out at that dose, not a potency): 68%
The estimate for compound 4 lay 2 percentage points above the measured number, and the stated range covers the measured number.
By their numbers in this assay, from the lowest: compounds 3, 2, 4 and 1 (each within the scatter of the next, the first and the last beyond it).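

In this assay, the change from 4-methoxyphenyl to 3,4,5-trimethoxyphenyl on the aromatic carbon of the five-membered ring can now be sized directly, and it gives a number 5 percentage points higher from compound 3 to compound 4 (within the scatter). The two other single changes can be read through the same compound: phenyl in place of ethyl on the aromatic nitrogen gives no change at the digits printed from compound 2 to compound 4 (within the scatter), and the group of 3 heavy atoms in place of the group of 4 heavy atoms on an aromatic carbon gives a number 7 percentage points lower from compound 1 to compound 4 (within the scatter). All three steps stay within the scatter, so none of these changes taken alone is shown to alter the inhibition at this single dose.

Nothing available bears on why these steps are as small as they are. On these data alone, it remains open whether an amine or a carboxylic acid on the aryl group at this aromatic carbon, or a longer chain in place of the ethyl on the aromatic nitrogen, would carry the number beyond the scatter.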